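From Methoxy to Fluoro: What to Expect for Compound 3

This account rests on a few compounds, and the source may have more. Where it says the series, first, only, none or still open, it means among the compounds named here.

Compound 2 `COc1ccc(NC(=S)N/N=C2\C(=O)Nc3ccc([N+](=O)[O-])cc32)cc1` holds the lower of the two numbers measured, and in a functional assay on the whole organism for inhibition, with Lemna aequinoctialis as the target, tested at 10 ug/mL (a lower number here means less inhibition of growth, a higher number more inhibition of growth at the concentration tested), compound 2 gives 10%. Its nearest neighbour is compound 1 `Cc1ccc(NC(=S)N/N=C2\C(=O)Nc3ccc([N+](=O)[O-])cc32)cc1`, which in this assay gives 15%; the gap between them, a number 5 percentage points lower from compound 1 to compound 2 (within the scatter), lies within the scatter. Compound 3 `O=C1Nc2ccc([N+](=O)[O-])cc2/C1=N/NC(=S)Nc1ccc(F)cc1` differs from compound 2 by fluoro in place of methoxy on an aromatic carbon. For the measured compounds named here, no measured step covers this exchange, and the one step available stayed within the scatter, so no shift beyond the scatter is expected in this assay. Compound 3 is estimated at 12%, between 0% and 30%. This amounts to an expected step of a number 2 percentage points higher from compound 2 to compound 3 (within the scatter).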

Compound 3, percent growth inhibition at one concentration: 5%
Compound 3: the middle estimate sits 7 percentage points above what was measured; the measured number falls inside the stated range.
By their numbers in this assay, from the lowest: compounds 3, 2 and 1 (each within the scatter of the next).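

In this assay fluoro in place of methoxy, on an aromatic carbon para to a large group, gives a number 5 percentage points lower from compound 2 to compound 3 (within the scatter) and fluoro in place of methyl gives a number 10 percentage points lower from compound 1 to compound 3 (within the scatter) on the same carbon. The earlier pair covered only methyl and methoxy, and with fluoro all three groups at this position now lie within the scatter of one another. Nothing available bears on the reason for this result. On these data alone, whether an amine or a carboxylic acid on this carbon would give a step beyond the scatter stays open, as does the effect of changes elsewhere on the shared core.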